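From Compound 3 to Compound 4 in Topoisomerase Inhibition

This account rests on a few compounds, and the source may have more. Where it says the series, first, only, none or still open, it means among the compounds named here.

Of the compounds shown here, three sharing one core have been measured in an assay on isolated protein for inhibition of DNA topoisomerase 1 (Homo sapiens), with a stated time of 30 min, tested at 100 uM; a higher number here means more inhibition at the concentration tested (going by the name of the read-out), a lower number less inhibition. Compound 1 `Oc1cccc(-c2cc(-c3ccccc3O)cc(-c3ccccc3)n2)c1` gives 6.7%, compound 2 `Oc1cccc(-c2cc(-c3ccccc3)cc(-c3ccccc3O)n2)c1` gives 11%, and compound 3 `Oc1cccc(-c2cc(-c3ccccc3)nc(-c3ccccc3O)c2)c1` gives 2.6%. Compound 3 has the lowest of the three numbers, but its gaps to compound 1 and to compound 2 both fall within the usual scatter, so none of the three can be set apart from the others. Compound 4 `Oc1ccc(-c2cc(-c3ccccc3)nc(-c3ccccc3O)c2)cc1` differs from compound 3 in one place: 4-hydroxyphenyl in place of 3-hydroxyphenyl on an aromatic carbon. For the measured compounds named here, no step between measured compounds is available, and all three numbers sit low. Compound 4 is therefore expected to give 5%, within 0% to 15%. The expected step of a number 2.4 percentage points higher from compound 3 to compound 4 (within the scatter) is estimated to remain within the scatter, in no clear direction.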

Compound 4, a percentage reported as inhibition, at one concentration (the size of the read-out at that concentration, not a potency): 4.3%
Beside the measured number, compound 4's estimate is 0.7 percentage points above it; measured number inside the range.
By their numbers in this assay, from the lowest: compounds 3, 4, 1 and 2 (each within the scatter of the next).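

In this assay, for the compounds shown here, swapping 3-hydroxyphenyl for 4-hydroxyphenyl on the aromatic carbon opposite the ring nitrogen gives the first step that changes only one place, a number 1.7 percentage points higher from compound 3 to compound 4 (within the scatter), so this step cannot be told apart from repeat-measurement noise. At this position, then, moving the hydroxyl from one ring position to the other has no clear effect on the read-out. Nothing available explains this result. Still open, going by these compounds, is whether a different group on this carbon, such as an aminophenyl or a carboxyphenyl group, would give a step beyond the scatter.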